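Trading hydroxy for methoxycarbonyl on a shared core

The source may hold more compounds than are shown below. What is called first, only, known or untested is meant among the compounds shown, and "the series" means these compounds.

In a functional assay on MM1 cells (Homo sapiens) for antiproliferative activity, read by MTT assay, with a stated time of 72 h (a higher number here means a weaker inhibitor, a lower number a stronger inhibitor), compound 1 (`N#C/C(=C\c1cccc(Br)n1)C(=O)N[C@@H]1CCc2ccccc21`) gives 2000 nM and compound 2 (`N#C/C(=C\c1cccc(Br)n1)C(=O)N[C@@H](CO)c1ccccc1`) gives 2800 nM. These two values lie within the usual scatter of each other, so compound 2 stands level with compound 1 on the numbers at hand. Compound 3 (`COC(=O)C[C@H](NC(=O)/C(C#N)=C/c1cccc(Br)n1)c1ccccc1`) departs from compound 2 by a single change, (methoxycarbonyl in place of hydroxy on a saturated chain carbon, two bonds along the chain from an amide-type nitrogen and an aromatic carbon), with methoxycarbonyl in place of hydroxy on a saturated chain carbon. For the measured compounds named here, no measured pair shows this change. Going by the values given here, the only guide is compound 1 at 2000 nM lying close to compound 2 at 2800 nM, so no step beyond the scatter is expected in this assay, in either direction. The estimated 1.3-fold lower number from compound 2 to compound 3 (0.10 log units; within the scatter) stays within that scatter. Compound 3 is expected at 2200 nM, within an estimated range of 900 nM to 5500 nM.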

Compound 3, half-maximal inhibitory concentration: 3100 nM
Compound 3: middle estimate off by 1.4-fold (0.15 log units), on the low side, and the stated range covers the measured number.
By their numbers in this assay, from the lowest: compounds 1, 2 and 3 (each within the scatter of the next).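

In this assay, putting methoxycarbonyl in place of hydroxy on a saturated chain carbon, two bonds along the chain from an amide-type nitrogen and an aromatic carbon, gives a 1.1-fold higher number from compound 2 to compound 3 (0.04 log units; within the scatter). This is the first pair shown that differs in one place, and it indicates that this position tolerates hydroxy, with its hydrogen-bond donor, being replaced by methoxycarbonyl, which has none, without a step beyond the scatter. Nothing at hand offers an explanation for this outcome.

Going by these compounds, it remains open whether a carboxylic acid, an amine or a longer chain at this position would also stay within the scatter of compound 2. On these data alone, it is equally open whether a plain methyl group there would do so, which would show whether either oxygen-bearing group matters to the number at all.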